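A few compounds are considered here, and "the series" means these few. Any claim that something is new, unique, unknown or untested is made for them only; others in the source may bear on it.

Compounds measured in an ADME assay on HeLa cells (Homo sapiens) for cytotoxicity, read by sulforhodamine B assay, with a stated time of 48 h, tested at 10 uM (a higher number here means more inhibition at the concentration tested (going by the name of the read-out), a lower number less inhibition), so far:

- compound 1, `CCCCc1cn(C(c2ccccc2)c2cc3cc(Br)ccc3nc2OC)nn1`, gives -2.87%
- compound 2, `CCCCCCCCc1cn(C(c2ccccc2)c2cc3cc(Br)ccc3nc2OC)nn1`, gives 0.1%
- compound 3, `CCCc1cn(C(c2ccccc2)c2cc3cc(Br)ccc3nc2OC)nn1`, gives -2.25%

All three numbers sit around zero inhibition and within the scatter of one another. The measured steps confirm this: a number 3 percentage points higher from compound 1 to compound 2 (within the scatter), a number 0.6 percentage points higher from compound 1 to compound 3 (within the scatter) and a number 2.4 percentage points lower from compound 2 to compound 3 (within the scatter) are all within the scatter, so lengthening or shortening the saturated chain on the shared core has shown no effect in this assay. Compound 3 stands second highest of the three numbers, nearest to compound 1 and furthest from compound 2, with both gaps within the scatter.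

Compound 4, `COc1nc2ccc(Br)cc2cc1C(c1ccccc1)n1cc(CCO)nn1`, is the next compound for this assay. It differs from compound 3 by hydroxy in place of methyl on a saturated chain carbon, two bonds along the chain from an aromatic carbon. Among the compounds with values here, none of the measured steps touches this kind of change: the three steps so far all vary the length of the chain, none introduces a hydroxy group. They do show, however, that changes at this chain have left the read-out flat across the whole series. Within the data shown here, with no step bearing directly on the change, the expectation is a step of no size beyond the scatter, a number 1.3 percentage points higher from compound 3 to compound 4 (within the scatter), and compound 4 is estimated at -1%, with a range from -10% to 8%.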

Compound 4, a percentage reported as inhibition, at one concentration (the size of the read-out at that concentration, not a potency): 0.85%
Beside the measured number, compound 4's estimate is 1.9 percentage points below it; measured number inside the range.
By their numbers in this assay, from the lowest: compounds 1, 3, 2 and 4 (each within the scatter of the next).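

In this assay, within the data shown here, the change from 4-propyl-1H-1,2,3-triazol-1-yl to 4-(2-hydroxyethyl)-1H-1,2,3-triazol-1-yl gives a number 3.1 percentage points higher from compound 3 to compound 4 (within the scatter), and this is the first step that alters what the chain is made of and not only its length. The comparisons with the two other alkyl chains read the same way, with a number 0.8 percentage points higher from compound 2 to compound 4 (within the scatter) and a number 3.7 percentage points higher from compound 1 to compound 4 (within the scatter), so at this position the hydroxy group, like the chain lengths before it, shows no effect on the read-out across compound 1, compound 2, compound 3 and compound 4. No measurement available here offers an explanation for this flat result.

From the compounds shown here alone, all four compounds sit near zero at the one concentration tested, so it remains open whether any group at this position can produce real inhibition in this assay. An amine or a carboxylic acid in place of the 2-hydroxyethyl chain would test this further, as would a replacement for the bromine or the phenyl group on the shared core.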